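Piperidinylmethyl for Chlorofluorobenzyl: Forecasting Compound 4

The source may hold more compounds than are shown below. What is called first, only, known or untested is meant among the compounds shown, and "the series" means these compounds.

Compound 1, `Cc1ccc2c(NCc3ccc(NC(=O)C4CCN(Cc5ccc(F)cc5)CC4)cc3)nc(N(C)C)nc2c1`, gives in a functional assay on SV5A8 cells (Homo sapiens) for cytotoxicity (on this read-out lower numbers stand for stronger inhibition and higher numbers for weaker inhibition), the limit > 4820 nM.
Compound 2, `Cc1ccc2c(NCc3ccc(NC(=O)C4CCN(C(=O)OC(C)(C)C)CC4)cc3)nc(N(C)C)nc2c1`, gives in this assay the limit > 4820 nM.
Compound 3, `Cc1ccc2c(NCc3ccc(NC(=O)C4CCN(Cc5ccc(F)cc5Cl)CC4)cc3)nc(N(C)C)nc2c1`, gives in this assay the limit > 5910 nM.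

Compound 3 stands at a limit, not at a number. Its two companions also sit at limits, as the limit of > 4820 nM in this assay, at which 2 of the 3 values shown sit, and the limit of > 5910 nM in this assay, at which 1 of the 3 values shown sits, show, so every value in this assay is a limit. The steps between them, a step that the two limits leave unreadable from compound 1 to compound 2, a step that the two limits leave unreadable from compound 1 to compound 3 and a step that the two limits leave unreadable from compound 2 to compound 3, therefore have no readable size.

Compound 4, `Cc1ccc2c(NCc3ccc(NC(=O)C4CCN(CC5CCNCC5)CC4)cc3)nc(N(C)C)nc2c1`, is not yet measured. It differs from compound 3 by piperidin-4-yl in place of 2-chloro-4-fluorophenyl on a saturated chain carbon bound to an amine nitrogen in a ring. The steps that touch the same place, the group on the amine nitrogen in a ring, are a step that the two limits leave unreadable from compound 1 to compound 3 and a step that the two limits leave unreadable from compound 2 to compound 3; both are unreadable, and neither the benzyl groups nor the tert-butoxycarbonyl group produced a number in this assay. Nothing among the three measured compounds therefore points in either direction for the piperidin-4-yl group.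

Compound 4 is accordingly expected to remain at or around a limit, with an estimated step that the limit leaves unreadable from compound 3 to compound 4. The estimate for compound 4 in this assay is 15000 nM, expected to lie between 4000 nM and 60000 nM.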

Compound 4, half-maximal inhibitory concentration: > 8070 nM
Compound 4 gave a limit, no number (the forecaster's own chance of this, stated with the estimate: 75%); the middle value does not contradict the limit.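

In this assay compound 4 gives > 8070 nM, which is a limit and not a number. With compound 1, compound 2 and compound 3 also at limits, none of the steps to compound 4 can be read. The compounds shown leave open whether any group on the amine nitrogen in a ring changes cytotoxicity, and by how much.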